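The compounds below may be only part of what the source reports. "The series", "measured", "known", "first", "only" and "open" are said of these compounds alone.

Working notes on the series. Going by the values given here, in a functional assay on SMMC-7721 cells (Homo sapiens) for antiproliferative activity, read by MTT assay, with a stated time of 72 h (on this read-out lower numbers stand for stronger inhibition and higher numbers for weaker inhibition), compound 2 `Cc1nn(C)c(Oc2ccc(F)cc2)c1/C=N\CCCCCCOc1cc2oc(=O)cc(C)c2cc1Cl` gives 13500 nM, and compound 1 `Cc1nn(C)c(Oc2cccc(F)c2)c1/C=N\CCCCCOc1cc2oc(=O)cc(C)c2cc1Cl` gives 11800 nM; the two numbers so far lie within the scatter of one another, so neither is set apart. Compound 3 `Cc1nn(C)c(Oc2ccc(F)c(F)c2)c1/C=N\CCCCCCOc1cc2oc(=O)cc(C)c2cc1Cl` differs from compound 2 by fluoro in place of hydrogen on an aromatic carbon. Among the compounds with values here, no step between measured compounds is known, and nothing among the two numbers points beyond the scatter in either direction. The step of a 1.2-fold lower number from compound 2 to compound 3 (0.09 log units; within the scatter) is therefore expected to stay within the scatter. Compound 3 is estimated at 11000 nM, with a range from 5500 nM to 24000 nM.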

Compound 3, half-maximal inhibitory concentration: > 25000 nM
Compound 3: only a limit was reported; the forecaster's own chance of this, stated with the estimate: 5%; middle value at least 2.2-fold (0.35 log units) away from the limit.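

Going by these compounds alone, this is the first single-place step: in this assay, 4-fluorophenoxy to 3,4-difluorophenoxy, with the new fluoro ortho to a fluoro group, gives an at least 1.8-fold higher number from compound 2 to compound 3 (0.26 log units; that floor lies within the scatter). This pair shows no stronger inhibition from fluoro at this aromatic carbon, but the true size of the step cannot be read. Compound 3 is reported only as a limit, not as a number: the limit of > 25000 nM in this assay, at which 1 of the 3 values shown sits.

Going by these compounds, whether chloro, methoxy or an amine on this carbon would behave like fluoro stays open. So does whether the step holds with a shorter chain.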